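A few compounds are considered here, and "the series" means these few. Any claim that something is new, unique, unknown or untested is made for them only; others in the source may bear on it.

Measured so far in a functional assay on C8166 cells (Homo sapiens) for cytotoxicity, read by MTT assay; on this read-out higher numbers stand for lower toxicity in this test and lower numbers for higher toxicity in this test:
- compound 1 `Cc1cc(S(N)(=O)=O)ccc1NC(=O)COc1ccc(Cl)cc1NC(=O)c1ccccc1C`: 67300 nM
- compound 2 `Cc1cc(S(N)(=O)=O)ccc1NC(=O)COc1ccc(Cl)cc1NC(=O)c1cccc(Cl)c1`: 59700 nM

The two compounds share one core and differ only in the aryl group on the amide carbonyl. Going by the values given here, compound 2, at 59700 nM, stands level with compound 1, and the only measured step, a 1.1-fold lower number from compound 1 to compound 2 (0.05 log units; within the scatter), does not separate them. That step replaced 2-methylphenyl with 3-chlorophenyl at the same carbonyl carbon.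

Compound 3 `COc1ccc(C(=O)Nc2cc(Cl)ccc2OCC(=O)Nc2ccc(S(N)(=O)=O)cc2C)cc1` changes this place again: 4-methoxyphenyl in place of 3-chlorophenyl on a carbonyl carbon. In words, it has 4-methoxyphenyl in place of 3-chlorophenyl on a carbonyl carbon. Among the compounds with values here, no measured compound carries this group, so the evidence is indirect and rests on two values alone. Within the data shown here, no step beyond the scatter is expected in this assay because a 1.1-fold lower number from compound 1 to compound 2 (0.05 log units; within the scatter) is the one precedent at this carbonyl carbon. The expected move is a 1.0-fold higher number from compound 2 to compound 3 (0.00 log units; within the scatter). For compound 3 the estimated value is 60000 nM, with an expected range of 33000 nM to 105000 nM.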

Compound 3, half-maximal cytotoxic concentration: 69500 nM
Compound 3: the middle estimate sits 1.2-fold (0.06 log units) below what was measured; measured number inside the range.
By their numbers in this assay, from the lowest: compounds 2, 1 and 3 (each within the scatter of the next).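

In this assay, the carbonyl carbon now carries a third aryl group: 4-methoxyphenyl in place of 3-chlorophenyl gives a 1.2-fold higher number from compound 2 to compound 3 (0.07 log units; within the scatter), and 4-methoxyphenyl in place of 2-methylphenyl gives a 1.0-fold higher number from compound 1 to compound 3 (0.01 log units; within the scatter). The earlier pair had shown only that a methyl-bearing and a chlorine-bearing phenyl stand level, whereas this result extends that finding to a group with an oxygen and one hydrogen-bond acceptor, so that the three compounds cannot be separated in this test and no order can be drawn among them at this position. Nothing measured here gives a reason for this flat result.

From the compounds shown here alone, all three groups at this carbonyl carbon are substituted phenyl rings, so it remains open whether an amine, a carboxylic acid or a cyclohexyl group there would produce a step beyond the scatter. All the steps also lie at this one place, which leaves open how the number would respond to a change elsewhere in the shared core, such as a carboxylic acid in place of the sulfonamide.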